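The source may report more compounds than this note shows. Statements on the series, on what has been measured and on what is new or still open speak of the compounds shown alone.

Measured so far: compound 1 `CC(C)(C)c1nn(CC(=O)Nc2sc3c(c2C(N)=O)CCCC3)cc1CNC1CC1` with 1580 nM; compound 2 `CN(C)Cc1cn(CC(=O)Nc2sc3c(c2C(N)=O)CCCC3)nc1C(C)(C)C` with 316 nM; compound 3 `CC(C)NCc1cn(CC(=O)Nc2sc3c(c2C(N)=O)CCCC3)nc1C(C)(C)C` with 1580 nM; all from an assay on isolated protein with metabotropic glutamate receptor 1 (Homo sapiens) as the target; on this read-out higher numbers stand for an effect only at larger amounts of compound and lower numbers for an effect already at smaller amounts.

Compound 3 stands level with compound 1, the two together giving the highest numbers of the three (no change at the digits printed from compound 1 to compound 3 (within the scatter)). Compound 2 sits apart from them: a 5.0-fold higher number from compound 2 to compound 3 (0.70 log units; beyond the scatter), and likewise a 5.0-fold lower number from compound 1 to compound 2 (0.70 log units; beyond the scatter).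

Compound 4 `CCNCc1cn(CC(=O)Nc2sc3c(c2C(N)=O)CCCC3)nc1C(C)(C)C` differs from compound 3 by hydrogen in place of methyl on a saturated chain carbon bound to an amine nitrogen and a saturated chain carbon. Among the compounds with values here, the step that bears on this most directly is the one from compound 1 to compound 3, which also exchanges one alkyl group for another on the same amine nitrogen and gives no change at the digits printed from compound 1 to compound 3 (within the scatter). The two steps that involve compound 2 both introduce dimethylamino in place of an amino group carrying one alkyl substituent, so they test a different kind of change and are less comparable; their size is noted but not taken as a guide here.

Since isopropyl and cyclopropyl on the amine nitrogen gave the same number, shortening isopropyl to ethyl is expected to leave this assay essentially unchanged, with an expected step of no change at the digits printed from compound 3 to compound 4 (within the scatter). The estimate for compound 4 is therefore 1580 nM, with an expected range from 600 nM to 4000 nM.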

Compound 4, half-maximal effective concentration: 794 nM
For compound 4 the middle estimate is 2.0-fold (0.30 log units) above the measured one; the measured number falls inside the stated range.
By their numbers in this assay, from the lowest: compound 2; then compounds 4, 1 and 3 (each within the scatter of the next).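

Working notes: in this assay the ethyl group on the amine nitrogen cannot be separated from the isopropyl group (a 2.0-fold lower number from compound 3 to compound 4 (0.30 log units; within the scatter)) or from the cyclopropyl group (a 2.0-fold lower number from compound 1 to compound 4 (0.30 log units; within the scatter)), so compounds 1, 3 and 4 form one level across these three groups at this position. Compound 2 stays apart even from the ethylamino compound (a 2.5-fold higher number from compound 2 to compound 4 (0.40 log units; beyond the scatter)), and together with its steps to compound 1 and compound 3, this sets dimethylamino apart from all three amines shown with a single alkyl group on the nitrogen. Nothing at hand accounts for this separation.

The compounds shown leave open what a methylamino group or an unsubstituted amino group would give on this chain carbon, and whether a longer chain such as n-butyl on the nitrogen would remain on the same level. They also leave open whether the separation of compound 2 extends to other amines with two substituents on the nitrogen, such as diethylamino or a pyrrolidine ring.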